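Chloro entering the urea partner of compound 3

This account rests on a few compounds, and the source may have more. Where it says the series, first, only, none or still open, it means among the compounds named here.

Compound 1 `COC(=O)c1ccc2c(ccn2-c2cccc(NC(=O)c3cccc(C(F)(F)F)c3)c2)n1`: > 10000 nM
Compound 2 `COC(=O)c1ccc2c(ccn2-c2ccc(NC(=O)Nc3ccc(Cl)c(C(F)(F)F)c3)cc2)n1`: 3600 nM
Compound 3 `COC(=O)c1ccc2c(ccn2-c2cccc(NC(=O)Nc3cccc(C(F)(F)F)c3)c2)n1`: > 10000 nM

In a functional assay on A375P cells (Homo sapiens) for cytotoxicity, read by MTT assay (a lower number here means a stronger inhibitor, a higher number a weaker inhibitor), compound 3 gives only a limit, > 10000 nM, and no number. Compound 1 likewise sits at a limit in this assay, > 10000 nM, so the step that the two limits leave unreadable from compound 1 to compound 3 stays unreadable; the limit of > 10000 nM in this assay, at which 2 of the 3 values shown sit, holds two of the three values. Among the measured compounds shown here, compound 2 is the one member of the set with a number, 3600 nM in this assay.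

Compound 4 `COC(=O)c1ccc2c(ccn2-c2cccc(NC(=O)Nc3ccc(Cl)c(C(F)(F)F)c3)c2)n1` carries the change chloro in place of hydrogen on an aromatic carbon, ortho to the trifluoromethyl group and para to a large group. For the measured compounds named here, no measured step bears directly on this change; compound 2 carries the same chloro-bearing ring but on a differently placed urea, so its value shows only that such a ring can give a number in this assay. The step of an at least 1.1-fold lower number from compound 3 to compound 4 (0.04 log units; that floor lies within the scatter) is therefore expected to be modest, and compound 3 offers only a limit to start from. Compound 4 is estimated at 9000 nM in this assay, within 3000 nM to 30000 nM.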

Compound 4, half-maximal inhibitory concentration: 9500 nM
Estimate against measurement, compound 4: 1.1-fold (0.02 log units) below; measured number inside the range.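

With the urea placed as in compound 3, chloro in place of hydrogen on an aromatic carbon, ortho to a trifluoromethyl group and para to a large group, yields a number in this assay: compound 4 gives 9500 nM. The change is read as an at least 1.0-fold lower number from compound 3 to compound 4 (0.02 log units; that floor lies within the scatter), so the data show no more than a floor on this step, and that floor does not establish a real gain. The full size of the step cannot be read, because compound 3 is recorded only as a limit: the limit of > 10000 nM in this assay, at which 2 of the 4 values shown sit.

The compounds shown leave open whether bromo, methyl or an amine on this same carbon would give a comparable number. They also leave open how a carboxylic acid in place of the methyl ester would read in this assay.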